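From Allyl to 2-Chloroethyl: Losing the Vinyl End

The compounds below may be only part of what the source reports. "The series", "measured", "known", "first", "only" and "open" are said of these compounds alone.

Within the data shown here, in a functional assay on K562 cells (Homo sapiens) for antiproliferative activity, read by MTT assay (a higher number here means a weaker inhibitor, a lower number a stronger inhibitor), compound 3 (`C=CCOC(=O)N1CCCc2cc(S(=O)(=O)N3CC(c4ccccc4)NC3=O)ccc21`) gives 473 nM as the only true number in this small set. Compound 1 (`CCOC(=O)N1CCCc2cc(S(=O)(=O)N3CC(c4ccccc4)NC3=O)ccc21`) stands at a limit (> 20000 nM). Compound 2 (`CCCOC(=O)N1CCCc2cc(S(=O)(=O)N3CC(c4ccccc4)NC3=O)ccc21`) also stands at a limit (> 20000 nM). Compound 4 (`O=C(OCCCl)N1CCCc2cc(S(=O)(=O)N3CC(c4ccccc4)NC3=O)ccc21`) differs from compound 3 in a single group (chloromethyl in place of vinyl on a saturated chain carbon bound to an oxygen next to a carbonyl group): chloromethyl in place of vinyl on a saturated chain carbon bound to an oxygen next to a carbonyl group. Among the measured compounds shown here, two measured steps bear on this change, both large and both bringing vinyl in: one from a methyl end (an at least 42-fold lower number from compound 1 to compound 3 (1.62 log units; beyond the scatter)) and one from an ethyl end (an at least 42-fold lower number from compound 2 to compound 3 (1.62 log units; beyond the scatter)). Read in reverse, they point to a higher number in this assay once vinyl leaves. Neither saturated chain carried chlorine, however, so the size stays uncertain and a limit value remains possible. The expected move is towards weaker inhibition (a 6.3-fold higher number from compound 3 to compound 4 (0.80 log units; beyond the scatter)). For compound 4 the estimated value is 3000 nM (expected range 400 nM to 20000 nM).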

Compound 4, half-maximal inhibitory concentration: 10600 nM
Compound 4: the middle estimate sits 3.5-fold (0.55 log units) below what was measured; measured number inside the range.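

In this assay, replacing allyl with 2-chloroethyl gives a 22-fold higher number from compound 3 to compound 4 (1.35 log units; beyond the scatter), so the weakening seen on losing the vinyl end also holds when the new chain end carries chlorine. Among these compounds, compound 4 is nevertheless the only compound with a saturated chain end here that gives a true number rather than a limit, with chloro in place of methyl giving an at least 1.8-fold lower number from compound 2 to compound 4 (0.27 log units; that floor lies within the scatter) and chloro in place of hydrogen giving an at least 1.8-fold lower number from compound 1 to compound 4 (0.27 log units; that floor lies within the scatter). Both of these steps are floors within the scatter, so neither establishes a real gain for compound 4 over the two compounds with saturated chain ends, since both of those compounds stand at a limit: the limit of > 20000 nM in this assay, at which 2 of the 4 values shown sit.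

From the compounds shown here alone, whether a 2-bromoethyl or 2-fluoroethyl end would read like 2-chloroethyl stays open. Also open, going by these compounds, is whether a propargyl end or a longer alkenyl chain would keep the number of compound 3.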